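A few compounds are considered here, and "the series" means these few. Any claim that something is new, unique, unknown or untested is made for them only; others in the source may bear on it.

In a functional assay on MCF7 cells (Homo sapiens) for cytotoxicity, read by sulforhodamine B assay (a higher number here means a weaker inhibitor, a lower number a stronger inhibitor), compound 1 `C=C1[C@@H](OC(C)=O)C[C@@H]2[C@](C)(CO[Si](C)(C)C(C)(C)C)[C@H](OC(C)=O)CC[C@@]2(C)[C@@H]1C[C@@H](Nc1ccc(Br)cc1)C1=CCOC1=O` gives 3920 nM, compound 2 `C=C1[C@@H](OC(C)=O)C[C@@H]2[C@](C)(CO[Si](C)(C)C(C)(C)C)[C@H](OC(C)=O)CC[C@@]2(C)[C@@H]1C[C@@H](Nc1ccccc1C(=O)O)C1=CCOC1=O` gives 4460 nM and compound 3 `C=C1[C@@H](OC(C)=O)C[C@@H]2[C@](C)(CO[Si](C)(C)C(C)(C)C)[C@H](OC(C)=O)CC[C@@]2(C)[C@@H]1C[C@@H](Nc1ccc(C(=O)O)cc1)C1=CCOC1=O` gives 3990 nM. Compound 3 therefore stands within the scatter of both others. The next structure is compound 4 `C=C1[C@@H](OC(C)=O)C[C@@H]2[C@](C)(CO[Si](C)(C)C(C)(C)C)[C@H](OC(C)=O)CC[C@@]2(C)[C@@H]1C[C@@H](Nc1cccc(OC)c1)C1=CCOC1=O`, with 3-methoxyphenyl in place of 4-carboxyphenyl on an amine nitrogen. Within the data shown here, the steps that bear on this change are a 1.0-fold higher number from compound 1 to compound 3 (0.01 log units; within the scatter), a 1.1-fold lower number from compound 2 to compound 3 (0.05 log units; within the scatter) and a 1.1-fold higher number from compound 1 to compound 2 (0.06 log units; within the scatter), all within the scatter and all made on that same nitrogen. Among the measured compounds shown here, none of the measured compounds carries a methoxy group, so this evidence is indirect. The expected step is a 1.0-fold lower number from compound 3 to compound 4 (0.01 log units; within the scatter), none beyond the scatter. For compound 4 the estimate is 3900 nM, with a range of 1800 nM to 7500 nM.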

Compound 4, half-maximal inhibitory concentration: 28100 nM
Compound 4: middle estimate off by 7.2-fold (0.86 log units), on the low side; the measured number lies above the stated range.
By their numbers in this assay, from the lowest: compounds 1, 3 and 2 (each within the scatter of the next); then compound 4.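

On the amine nitrogen, the aryl group matters in this assay: the steps are a 7.0-fold higher number from compound 3 to compound 4 (0.85 log units; beyond the scatter) and a 6.3-fold higher number from compound 2 to compound 4 (0.80 log units; beyond the scatter) and a 7.2-fold higher number from compound 1 to compound 4 (0.86 log units; beyond the scatter). Among these compounds, the earlier flat picture therefore holds only for 4-bromophenyl, 2-carboxyphenyl and 4-carboxyphenyl, and 3-methoxyphenyl is the first group at this position to move the number beyond the scatter. No measurement at hand accounts for this step.

Going by these compounds, whether the step belongs to the methoxy group or to its place on the ring stays open. Plain phenyl, or a hydroxy or amino group on that ring, would help separate the two.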